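Removing an Aromatic Methyl in a Thiourea Series

The compounds below may be only part of what the source reports. "The series", "measured", "known", "first", "only" and "open" are said of these compounds alone.

Compound 1 `CC1=C(C(=O)OCc2ccccc2)C(c2ccc(-c3ccccc3)cc2)N(Cc2ccc(-c3nnn[nH]3)cc2)C(=S)N1` was measured in a toxicity assay on RMS13 cells (Homo sapiens) for inhibition, with a stated time of 24 h (on this read-out lower numbers stand for stronger inhibition of growth and higher numbers for weaker inhibition of growth), and compound 1 gives 72000 nM.
Compound 2 `CC1=C(C(=O)OCc2ccccc2)C(c2ccc(-c3ccccc3C)cc2)N(Cc2ccc(-c3nnn[nH]3)cc2)C(=S)N1` in this assay gives 62000 nM.
Compound 3 `CC1=C(C(=O)OCc2ccccc2)C(c2ccc(-c3ccccc3C)cc2)NC(=S)N1CCCCCc1nnn[nH]1` in this assay gives 100000 nM.

Compounds 2 and 1 differ in one place: hydrogen in place of methyl on an aromatic carbon. The step that this change made is a 1.2-fold higher number from compound 2 to compound 1 (0.06 log units; within the scatter). Compound 3 has a different core from compound 2, and the difference between the two cores is not broken down here; the values of compound 3 and compound 2 in this assay lie close to one another.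

Compound 4 `CC1=C(C(=O)OCc2ccccc2)C(c2ccc(-c3ccccc3)cc2)NC(=S)N1CCCCCc1nnn[nH]1` has not yet been measured. It differs from compound 3 as follows: hydrogen in place of methyl on an aromatic carbon. The words describing the place of this change are the same as for the change from compound 2 to compound 1, so this is the same change applied to the other core. Among the compounds shown it occurs twice in all.

For the measured compounds named here, because a 1.2-fold higher number from compound 2 to compound 1 (0.06 log units; within the scatter), the expectation for compound 4 is a step of similar size, namely a 1.1-fold higher number from compound 3 to compound 4 (0.04 log units; within the scatter), resting on the single earlier example. The estimated value for compound 4 in this assay is 110000 nM, with an expected range from 45000 nM to 260000 nM.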

Compound 4, concentration for 50% growth inhibition: 110000 nM
Estimate against measurement, compound 4: no gap at the digits printed; the range from low to high includes it.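

In this assay, putting hydrogen in place of the methyl, which turns 2-methylphenyl into phenyl, gives a 1.1-fold higher number from compound 3 to compound 4 (0.04 log units; within the scatter), and this step can be set directly beside the one seen earlier on the other core: the same change on two cores in this assay, a 1.2-fold higher number (0.06 log units; within the scatter) from compound 2 to compound 1 and a 1.1-fold higher number (0.04 log units; within the scatter) from compound 3 to compound 4, 1.1-fold (0.02 log units) apart, within the scatter of two such steps Within this small set, then, the change carries from one core to the other without any readable difference in the size of the step, and on neither core does removing the methyl move the read-out beyond the usual scatter of repeated measurements. This does not show that the change has a real effect of a shared size, since two steps that both lie within the scatter agree about as well as two steps of no effect would, and two cores are too few to support a rule for the series as a whole.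

The compounds shown leave open whether anything other than hydrogen or methyl at this place on the aromatic ring, such as a chlorine atom, a methoxy group or an amine, would give a step beyond the scatter. They also leave open whether the same exchange would behave alike on a third core, or on the core of compound 3 with a longer chain.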